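A few compounds are considered here, and "the series" means these few. Any claim that something is new, unique, unknown or untested is made for them only; others in the source may bear on it.

Measured in a physicochemical assay for lipophilicity; a lower number here means a more polar compound, a higher number a more lipophilic compound:
- compound 1 `O=C1OCCN1c1cc(C(F)(F)F)ccc1[C@H]1CCOc2cc(S(=O)(=O)Nc3nccs3)ccc21`: 2.1
- compound 2 `Cc1nc(-c2cc(C(F)(F)F)ccc2[C@H]2CCOc3cc(S(=O)(=O)Nc4nccs4)ccc32)co1`: 2.9
- compound 3 `O=C1COCCN1c1cc(C(F)(F)F)ccc1[C@H]1CCOc2cc(S(=O)(=O)Nc3nccs3)ccc21`: 1.8

Compound 3 shares the low end of this range with compound 1, and the gap between them is small: a number 0.30 log units lower from compound 1 to compound 3 (within the scatter). Compound 2 stands well apart: a number 1.10 log units lower from compound 2 to compound 3 (beyond the scatter).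

Compound 4 `O=S(=O)(Nc1nccs1)c1ccc2c(c1)OCC[C@@H]2c1ccc(C(F)(F)F)cc1-n1ccnn1` carries 1H-1,2,3-triazol-1-yl in place of 3-oxomorpholin-4-yl on an aromatic carbon. For the measured compounds named here, no measured compound carries this group, so the evidence is indirect. All three measured steps change the group at this same place. Going by the values given here, the two that bear most directly involve 2-methyl-1,3-oxazol-4-yl, the only measured group that is not a 2-oxo-1,3-oxazolidin-3-yl or 3-oxomorpholin-4-yl: a number 0.80 log units higher from compound 1 to compound 2 (beyond the scatter), and a number 1.10 log units lower from compound 2 to compound 3 (beyond the scatter). The new group resembles neither closely, so a rise is expected that falls short of the full distance to compound 2 at 2.9. The expected step is a number 0.50 log units higher from compound 3 to compound 4 (beyond the scatter). For compound 4 the estimated value is 2.3, with an expected range of 1.8 to 2.8.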

Compound 4, distribution coefficient: 2.3
For compound 4 middle estimate and measured number coincide at the digits printed; the measured number falls inside the stated range.
By their numbers in this assay, from the lowest: compounds 3, 1 and 4 (each within the scatter of the next, the first and the last beyond it); then compound 2.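

At this position, on an aromatic carbon ortho to a large group and meta to a trifluoromethyl group, compound 4 shows that a second five-membered aromatic ring does not simply reproduce the number of compound 2 in this assay (a number 0.60 log units lower from compound 2 to compound 4 (beyond the scatter)). The 1H-1,2,3-triazol-1-yl group also separates the two non-aromatic lactam-type rings to different degrees, with a step beyond the scatter from one (a number 0.50 log units higher from compound 3 to compound 4 (beyond the scatter)) and one within it from the other (a number 0.20 log units higher from compound 1 to compound 4 (within the scatter)). Nothing measured here accounts for these steps.

The compounds shown leave open how much of the distance to compound 2 belongs to its methyl group and how much to its ring. They also leave open where a dimethylamino group or a carboxylic acid at this place would fall.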